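The source may report more compounds than this note shows. Statements on the series, on what has been measured and on what is new or still open speak of the compounds shown alone.

The measured compounds are compound 1 `COc1ccc(-c2sc(C(=O)O)cc2-c2cc(OC)c(OC)c(OC)c2)cc1OCc1ccccc1`, compound 2 `COc1ccc(-c2sccc2-c2cc(OC)c(OC)c(OC)c2)cc1OCc1ccccc1` and compound 3 `COc1ccc(-c2cc(C(=O)O)sc2-c2cc(OC)c(OC)c(OC)c2)cc1`.

In a functional assay on HT-1080 cells (Homo sapiens) for antiproliferative activity, read by MTT assay, with a stated time of 72 h (on this read-out lower numbers stand for stronger inhibition and higher numbers for weaker inhibition), compound 1 reaches only the limit > 100000 nM. Compound 2 likewise gives only the limit > 100000 nM in this assay. Among the measured compounds shown here, compound 3 gives 5810 nM in this assay, the only number among the three. The change from compound 1 to compound 2, (hydrogen in place of carboxy on an aromatic carbon), yields a step that the two limits leave unreadable from compound 1 to compound 2 because both values sit at the limit of > 100000 nM in this assay, at which 2 of the 3 values shown sit. The difference between the cores of compound 3 and compound 1 is not broken down here.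

Compound 4 `COc1ccc(-c2ccsc2-c2cc(OC)c(OC)c(OC)c2)cc1`, not yet measured, arises from compound 3 by the same kind of change, (hydrogen in place of carboxy on an aromatic carbon); around the place, the ring atom two ring bonds away bears a 4-methoxyphenyl group instead of a 3,4,5-trimethoxyphenyl group. For compound 4 the expected step is a 3.9-fold lower number from compound 3 to compound 4 (0.59 log units; beyond the scatter). This expectation rests only on compound 3 and its value 5810 nM, the earlier step being unreadable. Compound 4 is estimated at 1500 nM, expected between 100 nM and 20000 nM.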

Compound 4, half-maximal inhibitory concentration: 3620 nM
Compound 4: middle estimate off by 2.4-fold (0.38 log units), on the low side; measured number inside the range.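

In this assay, putting hydrogen in place of carboxy on the core of compound 3 gives a 1.6-fold lower number from compound 3 to compound 4 (0.21 log units; within the scatter), so the two values cannot be told apart on this core. On the core of compound 1 the same change cannot be read, since compound 1 and compound 2 both stand only at a limit: the limit of > 100000 nM in this assay, at which 2 of the 4 values shown sit.

This leaves a single readable instance of the change, and it does not show that the step carries from one core to another. The compounds shown leave open what other groups would give on this aromatic carbon next to the ring sulfur, such as a primary amide, a nitrile or an aminomethyl group. They also leave open whether a methyl ester there would match the carboxy or the hydrogen compounds.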